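This account rests on a few compounds, and the source may have more. Where it says the series, first, only, none or still open, it means among the compounds named here.

Going by the values given here, compound 3 `COc1ccc(Cl)cc1N(CC(=O)NC1CCCCC1)S(=O)(=O)c1ccccc1` carries the only numerical reading in the set: in a functional assay on SH-SY5Y cells (Homo sapiens), read by MTT assay, with a stated time of 24 h (a lower number here means that less compound is needed, a higher number that more compound is needed for the effect), compound 3 gives 17600 nM. Compound 1 `COc1ccc(Cl)cc1N(CC(=O)N1CCc2ccccc21)S(=O)(=O)c1ccccc1` stops at the limit of this assay, compound 1 giving > 20000 nM. Compound 2 `COc1ccc(CNC(=O)CN(c2cc(Cl)ccc2OC)S(=O)(=O)c2ccccc2)cc1` likewise stops at the limit, compound 2 giving > 20000 nM. Both rest at the limit of > 20000 nM in this assay, at which 2 of the 3 values shown sit. The steps of an at least 1.1-fold lower number from compound 1 to compound 3 (0.05 log units; that floor lies within the scatter) and an at least 1.1-fold lower number from compound 2 to compound 3 (0.05 log units; that floor lies within the scatter) are floors within the scatter, and a step that the two limits leave unreadable from compound 1 to compound 2 cannot be read. Compound 4 `COc1cccc(NC(=O)CN(c2cc(Cl)ccc2OC)S(=O)(=O)c2ccccc2)c1` differs from compound 3 by 3-methoxyphenyl in place of cyclohexyl on an amide-type nitrogen. The nearest measured step is an at least 1.1-fold lower number from compound 2 to compound 3 (0.05 log units; that floor lies within the scatter), where the aromatic amide substituent sat at the limit; the expected step of a 1.1-fold higher number from compound 3 to compound 4 (0.06 log units; within the scatter) is therefore upward, back toward that limit. Compound 4 is expected at 20000 nM, with a range from 8000 nM to 50000 nM.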

Compound 4, half-maximal effective concentration: 17600 nM
Compound 4: middle estimate off by 1.1-fold (0.06 log units), on the high side; the measured number falls inside the stated range.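

At the amide-type nitrogen, 3-methoxyphenyl in place of cyclohexyl leaves the reading in this assay unmoved (no change at the digits printed from compound 3 to compound 4 (within the scatter)), so a six-membered aromatic ring is tolerated here as well as a non-aromatic one. Against the two limit compounds only floors can be read (an at least 1.1-fold lower number from compound 2 to compound 4 (0.05 log units; that floor lies within the scatter)) and (an at least 1.1-fold lower number from compound 1 to compound 4 (0.05 log units; that floor lies within the scatter)), and the true size of these steps stays open: the limit of > 20000 nM in this assay, at which 2 of the 4 values shown sit. The compounds shown leave open whether any substituent on this nitrogen moves the reading beyond the scatter. A phenyl ring carrying an amine or a carboxylic acid would test this.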